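Shifting the Chlorine: From Compound 3 to Compound 4

This account rests on a few compounds, and the source may have more. Where it says the series, first, only, none or still open, it means among the compounds named here.

The set comprises four compounds built on a shared core. Compound 1 `Oc1cccc(-c2cc(-c3ccncc3)nc(-c3cccc(Cl)c3)c2)c1` has no result reported in a functional assay on DU-145 cells (Homo sapiens) for cytotoxicity, read by CCK-8 assay and cell counting, with a stated time of 2 days; a higher number here means a weaker inhibitor, a lower number a stronger inhibitor: its entry there reads "not determined" (no result reported). Compound 2 `Oc1cccc(-c2cc(-c3cccc(Cl)c3)nc(-c3ccccn3)c2)c1` likewise has no result reported, and in this assay compound 2 stands at "not determined" (no result reported). Among the measured compounds shown here, compound 3 `Oc1cccc(-c2cc(-c3ccccc3)nc(-c3ccc(Cl)cc3)c2)c1` is thus the only member with a number: in this assay compound 3 gives 11200 nM, a weak effect, and as the single value shown it is the sole reference point, with nothing to rank it against.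

Compound 4 `Oc1cccc(-c2cc(-c3ccccc3)nc(-c3cccc(Cl)c3)c2)c1` is the compound still to be measured. It differs from compound 3 in one respect only: 3-chlorophenyl in place of 4-chlorophenyl on an aromatic carbon. The two have the same atoms, joined differently.

For the measured compounds named here, no step between two measured compounds is available, so there is no precedent within this set for what moving the chlorine does to cytotoxicity. Going by the values given here, with a change this small and only one number on record, the expectation is a step that stays inside the usual scatter, in no particular direction. The author therefore expects the step from compound 3 to compound 4 to be a 1.1-fold lower number from compound 3 to compound 4 (0.05 log units; within the scatter), essentially flat. On that basis compound 4 is estimated at 10000 nM in this assay. For compound 4 the range of that estimate runs from 4000 nM to 30000 nM.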

Compound 4, half-maximal inhibitory concentration: 2750 nM
For compound 4 the middle estimate is 3.6-fold (0.56 log units) above the measured one; the whole stated range lies above it.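

Moving the chlorine on this phenyl group is not a neutral change: replacing 4-chlorophenyl with 3-chlorophenyl in this assay gives a 4.1-fold lower number from compound 3 to compound 4 (0.61 log units; beyond the scatter). Among the compounds shown here, this is the only step that can be read here, and it shows that the read-out at this aromatic carbon, next to the ring nitrogen, responds to where the chlorine sits, even though the group that leaves and the group that enters have the same heavy atoms and the same counts of hydrogen-bond donors and acceptors. Nothing given here accounts for this difference, so the step stands as an observation without an explanation.

As far as these compounds go, compound 1 and compound 2 also carry 3-chlorophenyl, but their entries hold no number, so any steps involving them cannot be read, and whether the effect of moving the chlorine extends to other members remains unknown. Also open, from the compounds shown here alone, is how this position would respond to 2-chlorophenyl, or to a group other than chlorine on the phenyl ring, such as a methoxy group, an amine or a carboxylic acid.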